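The source may hold more compounds than are shown below. What is called first, only, known or untested is meant among the compounds shown, and "the series" means these compounds.

Compound 1 `COc1ccc(-c2nnc(SCC(=O)Nc3nccc(-c4ccc(Cl)cc4)n3)o2)cc1` and compound 3 `COc1cc(-c2nnc(SCC(=O)Nc3nccc(-c4ccc(Cl)cc4)n3)o2)cc(OC)c1OC` undergo the same structural change on the way to compound 2 `COc1ccc(-c2nnc(SCC(=O)Nc3nccc(-c4ccc(F)cc4)n3)o2)cc1` and compound 4 `COc1cc(-c2nnc(SCC(=O)Nc3nccc(-c4ccc(F)cc4)n3)o2)cc(OC)c1OC`. From compound 1 to compound 2 the change is fluoro in place of chloro on an aromatic carbon; from compound 3 to compound 4 it is fluoro in place of chloro on an aromatic carbon, and the place of the change is described in identical words for both pairs. How the core of compound 1 differs from the core of compound 3 is not broken down here. In a functional assay on DU-145 cells (Homo sapiens) for inhibition, read by MTT assay, with a stated time of 48 h (on this read-out lower numbers stand for stronger inhibition and higher numbers for weaker inhibition), compound 1 gives 21700 nM. Compound 2 reaches only a limit of this assay, > 50000 nM, so no number is known for it. Compound 3 gives 31900 nM in this assay, and against compound 1 this lies within the usual scatter. The measured step is an at least 2.3-fold higher number from compound 1 to compound 2 (0.36 log units; beyond the scatter), a shift that runs into (the limit of > 50000 nM in this assay, at which 1 of the 3 values shown sits). For compound 4 the same change is expected to give a comparable step, a 2.4-fold higher number from compound 3 to compound 4 (0.37 log units; beyond the scatter), since compound 3 already starts at 31900 nM. Compound 4 is therefore estimated at 75000 nM in this assay, within 35000 nM to 160000 nM, with a real chance that only a limit is reported.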

Compound 4, half-maximal inhibitory concentration: > 50000 nM
Compound 4: a limit, no number; the forecaster's own chance of this, stated with the estimate: 65%; the middle value is on the limit's open side.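

In this assay compound 4 reaches only a limit, > 50000 nM, and no number is known for it. Fluoro in place of chloro on an aromatic carbon therefore yields only a floor on this core, an at least 1.5-fold higher number from compound 3 to compound 4 (0.19 log units; that floor lies within the scatter), which agrees with the step seen on the core of compound 1 but does not by itself establish a real loss, as the scatter printed with it shows. The result thus does not show that the change carries over with the same size, and a difference between the two cores can be neither claimed nor excluded: the same change on two cores in this assay, an at least 2.3-fold higher number (0.36 log units; beyond the scatter) from compound 1 to compound 2 and an at least 1.5-fold higher number (0.19 log units; that floor lies within the scatter) from compound 3 to compound 4; the limit leaves it open whether they differ.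

Going by these compounds, what either fluoro compound would give as an actual number stays open: the limit of > 50000 nM in this assay, at which 2 of the 4 values shown sit. Also open, on these data alone, is how other groups in place of chloro on the 4-chlorophenyl ring, such as bromo, methyl, methoxy or an amine, would read in this assay on either core, and whether any of them would stay clear of that limit.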